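The source may hold more compounds than are shown below. What is called first, only, known or untested is meant among the compounds shown, and "the series" means these compounds.

Of the compounds shown here, three with a shared core have been measured in a functional assay on PC-3 cells (Homo sapiens) for inhibition, read by MTT assay, with a stated time of 48 h; a higher number here means a weaker inhibitor, a lower number a stronger inhibitor. Compound 1 `COc1ccc(-n2c(S)nnc2-c2cc(OC)c(OC)c(OC)c2)cc1` gives > 60000 nM, which is a limit of the assay and not a number. Compound 2 `CCSc1nnc(-c2cc(OC)c(OC)c(OC)c2)n1-c1ccc(OC)cc1` gives 57700 nM. Going by the values given here, compound 3 `COc1ccc(CSc2nnc(-c3cc(OC)c(OC)c(OC)c3)n2-c2ccc(OC)cc2)cc1` gives 40300 nM, and it and compound 2 are the only two with true numbers, lying within the scatter of each other.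

Compound 4 `COc1ccc(-n2c(SCC(=O)c3ccccc3)nnc2-c2cc(OC)c(OC)c(OC)c2)cc1` has not yet been measured in this assay. Its difference from compound 3 is this: benzoyl in place of 4-methoxyphenyl on a saturated chain carbon bound to a sulfur. Benzoyl thus stands in place of 4-methoxyphenyl on a saturated chain carbon bound to a sulfur.

The closest measured change, at that same carbon, is a 1.4-fold lower number from compound 2 to compound 3 (0.16 log units; within the scatter). Two further changes, both replacing the hydrogen on the sulfur, are an at least 1.0-fold lower number from compound 1 to compound 2 (0.01 log units; that floor lies within the scatter) and an at least 1.4-fold lower number from compound 1 to compound 3 (0.17 log units; that floor lies within the scatter). Neither these two nor the closest change goes beyond the scatter, so no step beyond the scatter is expected in this assay, and no direction can be favoured with confidence.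

Compound 4 is expected at 38000 nM, with an estimated range of 14000 nM to 70000 nM. The expected change is a 1.1-fold lower number from compound 3 to compound 4 (0.03 log units; within the scatter).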

Compound 4, half-maximal inhibitory concentration: > 60000 nM
Compound 4: no number, only a limit; the forecaster's own chance of this, stated with the estimate: 25%; middle value at least 1.5-fold (0.19 log units) away from the limit.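

Going by these compounds alone, the change at this carbon had so far given only a step within the scatter towards a lower number, and benzoyl is the first group there whose floor points the other way: benzoyl in place of 4-methoxyphenyl gives an at least 1.4-fold higher number from compound 3 to compound 4 (0.17 log units; that floor lies within the scatter), and benzoyl in place of methyl gives an at least 1.0-fold higher number from compound 2 to compound 4 (0.01 log units; that floor lies within the scatter). Both steps are floors, so the data show that swapping 4-methoxyphenyl for benzoyl, which have the same heavy-atom count and differ by a carbonyl and a methoxy group, brought no gain, but they do not show a real loss. Compound 4 gives a limit and not a number, and the step from compound 1 to compound 4 cannot be read, so everything said of it rests on the ceiling of the read-out: the limit of > 60000 nM in this assay, at which 2 of the 4 values shown sit.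

The compounds shown leave open how large the step to compound 4 really is, and whether it goes with the carbonyl that enters or the methoxy group that leaves. A 4-methoxybenzoyl group on the same saturated chain carbon bound to a sulfur would separate these two readings, and a carboxylic acid there would test a different kind of group at this carbon.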